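Cytotoxicity notes: from compound 2 to compound 4

The source may report more compounds than this note shows. Statements on the series, on what has been measured and on what is new or still open speak of the compounds shown alone.

Measured in an ADME assay on THP-1 cells (Homo sapiens) for cytotoxicity; on this read-out lower numbers stand for higher toxicity in this test and higher numbers for lower toxicity in this test:
compound 1 `COc1ccn2c(Nc3cc(Cl)ccc3Cl)c(-c3ccccn3)nc2c1` gives 8930 nM
compound 2 `c1cncc(-c2nc3ccccn3c2NC2CCCC2)c1` gives > 50000 nM
compound 3 `Cc1ccn2c(NC3CCCC3)c(-c3ccc(N(C)C)cc3)nc2c1` gives > 50000 nM

The entry for compound 2 is a limit of this assay, not a number. The entry for compound 3 is likewise a limit. Going by the values given here, compound 2 therefore stands only at the limit of > 50000 nM in this assay, at which 2 of the 3 values shown sit, together with compound 3, while compound 1 is the one entry with a number beneath that limit. Among the compounds with values here, no two of the measured compounds differ in a single place, so no measured step exists in this assay.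

Compound 4 `Fc1ccccc1-c1nc2ccccn2c1NC1CCCC1` differs from compound 2 by 2-fluorophenyl in place of pyridin-3-yl on an aromatic carbon, in words 2-fluorophenyl in place of pyridin-3-yl on an aromatic carbon. Within the data shown here, with no measured step to lean on, the step in this assay is expected to be small, without a direction that can be called beyond the usual scatter, so compound 4 is expected to remain near the limit at which compound 2 sits. The estimate for compound 4 is 40000 nM, between 15000 nM and 60000 nM, which is expected to amount to an at least 1.2-fold lower number from compound 2 to compound 4 (0.09 log units; that floor lies within the scatter).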

Compound 4, half-maximal cytotoxic concentration: > 50000 nM
Compound 4 was reported as a limit; the forecaster's own chance of this, stated with the estimate: 45%; middle value at least 1.2-fold (0.09 log units) from the limit.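

Compound 2 and compound 4 are both entries that are limits, not numbers, in this assay, so no step can be read between them. The compounds shown leave open whether 2-fluorophenyl in place of pyridin-3-yl changes cytotoxicity at all, and which difference sets compound 1 apart from the limit.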